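A few compounds are considered here, and "the series" means these few. Any claim that something is new, unique, unknown or untested is made for them only; others in the source may bear on it.

Measured so far:
Compound 1 `NS(=O)(=O)c1ccc(N/C(S)=N\c2ccnc3cc(C(F)(F)F)ccc23)cc1` gives 34500 nM in a functional assay on LoVo cells (Homo sapiens) for antiproliferative activity, read by sulforhodamine B assay, with a stated time of 48 h; a lower number here means a stronger inhibitor, a higher number a weaker inhibitor.
Compound 2 `CC(=O)NS(=O)(=O)c1ccc(N/C(S)=N\c2ccnc3cc(C(F)(F)F)ccc23)cc1` gives 30000 nM in this assay.
Compound 3 `Cc1noc(NS(=O)(=O)c2ccc(N/C(S)=N\c3ccnc4cc(C(F)(F)F)ccc34)cc2)c1C` gives 67100 nM in this assay.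

Compound 3 stands at the highest of the three numbers, with compound 1 nearest and compound 2 furthest. The step of a 1.9-fold higher number from compound 1 to compound 3 (0.29 log units; within the scatter) lies within the scatter, while a 2.2-fold higher number from compound 2 to compound 3 (0.35 log units; beyond the scatter) is modest and beyond it. Compound 4 `O=S(=O)(Nc1ccccn1)c1ccc(N/C(S)=N\c2ccnc3cc(C(F)(F)F)ccc23)cc1` differs from compound 3 by pyridin-2-yl in place of 3,4-dimethyl-1,2-oxazol-5-yl on a sulfonamide nitrogen. Both measured steps onto that sulfonamide nitrogen bear on this change, and both were small, so the account expects compound 4 to move little in this assay, perhaps toward the lower numbers of compounds 1 and 2. Compound 4 is expected to give 40000 nM, within 15000 nM to 110000 nM. That estimate means an expected step of a 1.7-fold lower number from compound 3 to compound 4 (0.22 log units; within the scatter).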

Compound 4, half-maximal inhibitory concentration: 87500 nM
Estimate against measurement, compound 4: 2.2-fold (0.34 log units) below, within the range that was stated.
By their numbers in this assay, from the lowest: compounds 2, 1, 3 and 4 (each within the scatter of the next, the first and the last beyond it).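

In this assay, pyridin-2-yl in place of 3,4-dimethyl-1,2-oxazol-5-yl on the sulfonamide nitrogen gives a 1.3-fold higher number from compound 3 to compound 4 (0.12 log units; within the scatter), so the two aromatic rings are not told apart here. The other two steps, a 2.5-fold higher number from compound 1 to compound 4 (0.40 log units; beyond the scatter) and a 2.9-fold higher number from compound 2 to compound 4 (0.46 log units; beyond the scatter), show that a group on this nitrogen can move the number beyond the scatter from the hydrogen of compound 1, which neither earlier group did. Nothing available explains these steps.

The compounds shown leave open how a cyclohexyl ring or a longer alkyl chain on this nitrogen would compare. They also leave open whether any group there gives a number well below those of compound 1 and compound 2.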